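Working notes: from compound 2 to compound 4

The source may report more compounds than this note shows. Statements on the series, on what has been measured and on what is new or still open speak of the compounds shown alone.

- compound 1 `C/C=C(\C)C(=O)O[C@H]1C[C@@](C)(O)[C@]23C=C[C@](C)([C@@H]2[C@H]2OC(=O)[C@@H](C)[C@@H]21)[C@]1(C3)C(=O)O[C@@H]2[C@H]3C(C)=CC[C@H]3[C@](C)(O)C[C@H](O)[C@H]21`: > 10000 nM
- compound 2 `C=C1C(=O)O[C@H]2[C@H]1[C@@H](OC(=O)/C(C)=C/C)C[C@@](C)(O)[C@]13C=C[C@](C)([C@H]21)[C@]1(C3)C(=O)O[C@@H]2[C@H]3C(C)=CC[C@H]3[C@](C)(O)C[C@H](O)[C@H]21`: > 10000 nM
- compound 3 `C=C1C(=O)O[C@H]2[C@H]1[C@@H](O)C[C@@](C)(O)[C@]13C=C[C@](C)([C@H]21)[C@]1(C3)C(=O)O[C@@H]2[C@H]3C(C)=CC[C@H]3[C@](C)(O)C[C@H](OC(=O)/C(C)=C\C)[C@H]21`: > 10000 nM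

All three compounds were measured in a functional assay on SUNE1 cells (Homo sapiens) for cytotoxicity, read by MTT assay, with a stated time of 48 h (a lower number here means a stronger inhibitor, a higher number a weaker inhibitor), and none gives a number. Compound 2 stands at > 10000 nM, which is a limit. The whole set shows (the limit of > 10000 nM in this assay, at which 3 of the 3 values shown sit). For the measured compounds named here, no measured step is therefore available to size a structural change.

Compound 4 `C=C1C(=O)O[C@H]2[C@H]1[C@@H](OC(=O)/C(C)=C/C)C[C@@](C)(O)[C@]13C=C[C@](C)([C@H]21)[C@]1(C3)C(=O)O[C@@H]2[C@H]3C(C)=CC[C@H]3[C@](C)(O)C[C@H](OC(=O)/C(C)=C/C)[C@H]21` is the next compound to be read in this assay. It differs from compound 2 as follows: (1-methylprop-1-en-1-yl)carbonyl in place of hydrogen on an oxygen on a saturated carbon. In words, (1-methylprop-1-en-1-yl)carbonyl takes the place of hydrogen on an oxygen on a saturated carbon, so hydroxy becomes ((1-methylprop-1-en-1-yl)carbonyl)oxy.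

The expectation rests on compound 2 at > 10000 nM, again a limit. No change beyond the scatter is expected in either direction, and the expected step is a step that the limit leaves unreadable from compound 2 to compound 4. The assay may well report only a limit again. For compound 4 the estimate is 12000 nM, with an expected range of 5000 nM to 30000 nM.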

Compound 4, half-maximal inhibitory concentration: 4300 nM
Estimate against measurement, compound 4: 2.8-fold (0.45 log units) above; the whole stated range lies above it.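

In this assay, the change from hydroxy to ((1-methylprop-1-en-1-yl)carbonyl)oxy on this oxygen gives an at least 2.3-fold lower number from compound 2 to compound 4 (0.36 log units; beyond the scatter). This is the first change in the series shown to move the read-out off the limit. For the compounds shown here, compound 4 is the only compound here with a number, at 4300 nM. The step has a lower bound only, and its true size stays unknown: the limit of > 10000 nM in this assay, at which 3 of the 4 values shown sit.

Open, as far as these compounds go, is whether an acetyl group, a longer chain or an ester carrying an amine on this oxygen would give a similar step. Also open, from the compounds shown here alone, is whether the same change would give a step on a compound lacking the ester already present in compound 2.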